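Halogen pattern on the aryl ring of a short amide series

This account rests on a few compounds, and the source may have more. Where it says the series, first, only, none or still open, it means among the compounds named here.

Three measured compounds share one core and differ only in the halogens on the six-membered aromatic ring of carbon only. In an assay on isolated protein for inhibition of alkaline phosphatase, tissue-nonspecific isozyme (Homo sapiens) (on this read-out lower numbers stand for stronger inhibition and higher numbers for weaker inhibition), compound 1 `O=C(NCCO)c1cc(-c2ccc(Cl)cc2Cl)n[nH]1` gives 44 nM. In this assay compound 2 `O=C(NCCO)c1cc(-c2cc(F)c(Cl)cc2Cl)n[nH]1` gives 100 nM, and compound 3 `O=C(NCCO)c1cc(-c2cc(F)c(F)cc2F)n[nH]1` gives 134 nM; compound 3 has the highest number of the three, its gap to compound 2 lying within the scatter and its gap to compound 1 beyond it. The difference between the cores of compound 3 and compound 2 is not broken down here. The change hydrogen in place of fluoro on an aromatic carbon gave a 2.3-fold lower number from compound 2 to compound 1 (0.36 log units; beyond the scatter). Compound 4 `O=C(NCCO)c1cc(-c2ccc(F)cc2F)n[nH]1` is not yet measured; from compound 3 it differs by hydrogen in place of fluoro on an aromatic carbon, the same kind of change, though here the place is ortho to a fluoro group and para to a fluoro group, whereas in the earlier pair it was ortho to a chloro group and para to a chloro group. Among the compounds with values here, a step of similar size is expected for compound 4, namely a 2.1-fold lower number from compound 3 to compound 4 (0.31 log units; beyond the scatter), because a 2.3-fold lower number from compound 2 to compound 1 (0.36 log units; beyond the scatter) is the only measured step of this kind. Compound 4 is therefore estimated at 65 nM, with a likely range from 30 nM to 140 nM.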

Compound 4, half-maximal inhibitory concentration: 35 nM
Estimate against measurement, compound 4: 1.9-fold (0.27 log units) above; the range from low to high includes it.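

In this assay, hydrogen in place of fluoro on an aromatic carbon gave a 3.8-fold lower number from compound 3 to compound 4 (0.58 log units; beyond the scatter). The change carries from one core to the other in the same direction, and the two steps do not differ in size beyond the scatter: the same change on two cores in this assay, a 2.3-fold lower number (0.36 log units; beyond the scatter) from compound 2 to compound 1 and a 3.8-fold lower number (0.58 log units; beyond the scatter) from compound 3 to compound 4, 1.7-fold (0.23 log units) apart, within the scatter of two such steps

Within the data shown here, this rests on only two pairs, with the change ortho to a chloro group and para to a chloro group in one and ortho to a fluoro group and para to a fluoro group in the other, so it shows no transfer to other places on the ring or to cores with a different amide chain, and it gives no reason for the step.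

The compounds shown leave open whether a bromo, methyl or methoxy group on the ring would fit the same trend as the two halogens seen here. They also leave open how the step would behave with an amine or a carboxylic acid in place of the hydroxyl at the end of the amide chain, or with a longer chain.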